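Fluorine Position and Antiproliferative Effect in Compound 4

The source may report more compounds than this note shows. Statements on the series, on what has been measured and on what is new or still open speak of the compounds shown alone.

Measured compounds:
compound 1 `Nc1ccccc1NC(=O)c1ccc(CSC(=S)N2CCc3ccccc32)cc1`: 87%
compound 2 `CN(C(=S)SCc1ccc(C(=O)Nc2ccccc2N)cc1)c1cccnc1`: 82.5%
compound 3 `Nc1ccccc1NC(=O)c1ccc(CSC(=S)N2CCN(c3ccc(F)cc3)CC2)cc1`: 48.7%

Of the compounds shown here, three sharing one core have been tested in a functional assay on MGC-803 cells (Homo sapiens) for antiproliferative activity, read by CCK-8 assay, with a stated time of 72 h, tested at 8 uM; a lower number here means a weaker effect, a higher number a stronger effect of the compound at the concentration tested. Compound 1 gives 87%, and compound 2 gives 82.5%; the step of a number 4.5 percentage points lower from compound 1 to compound 2 (within the scatter) lies within the scatter. Compound 3 stands lowest of the three, with 48.7%, well apart from both of the others.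

Compound 4 `Nc1ccccc1NC(=O)c1ccc(CSC(=S)N2CCN(c3ccccc3F)CC2)cc1` has not yet been measured. Its difference from compound 3 is 2-fluorophenyl in place of 4-fluorophenyl on an amine nitrogen in a ring. Among the compounds with values here, no measured step touches this part of the molecule: the one measured step, a number 4.5 percentage points lower from compound 1 to compound 2 (within the scatter), concerns the group on the thiocarbonyl carbon and was within the scatter. Nothing in the measured data therefore speaks for a step beyond the scatter in this assay from compound 3 to compound 4, and the expectation is a number 1.3 percentage points higher from compound 3 to compound 4 (within the scatter). On this basis compound 4 is estimated at 50%, with a range from 30% to 72%, which is wide because only the value of compound 3 , 48.7%, anchors it.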

Compound 4, a percentage reported as inhibition, at one concentration (the size of the read-out at that concentration, not a potency): 86.4%
Compound 4: middle estimate off by 36.4 percentage points, on the low side, outside the stated range (above it).
By their numbers in this assay, from the lowest: compound 3; then compounds 2, 4 and 1 (each within the scatter of the next).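

In this assay, the step of a number 37.7 percentage points higher from compound 3 to compound 4 (beyond the scatter) shows that the place of the fluorine alone can decide the result: 2-fluorophenyl in place of 4-fluorophenyl, with the same atoms joined differently, is a large change. Within the data shown here, the only earlier step, a number 4.5 percentage points lower from compound 1 to compound 2 (within the scatter), lay at the thiocarbonyl carbon and stayed within the scatter, so it gave no sign that the far end of the molecule could respond this strongly; since compound 4 keeps the ring with 2 nitrogen, that ring alone does not fix the low number of compound 3. Nothing measured here accounts for the size of this step.

The compounds shown leave open whether a plain phenyl, a 2-chlorophenyl or a 2-methoxyphenyl on that amine nitrogen would give a number nearer that of compound 3 or that of compound 4. With a read-out at one concentration, they also leave open how the potency of compound 4 compares with that of compound 3.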